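A dihydroxyphenyl group in place of 4-methoxyphenyl

The source may hold more compounds than are shown below. What is called first, only, known or untested is meant among the compounds shown, and "the series" means these compounds.

compound 1 `COc1ccc(-c2cc(-c3ccc(OC)c(OC)c3)cc(=O)[nH]2)c(OC)c1` - 1000 nM
compound 2 `COc1ccc(-c2cc(-c3ccc(OC)cc3OC)[nH]c(=O)c2)cc1` - 500 nM
compound 3 `CCCOc1ccc(-c2cc(-c3ccc(OC)cc3OC)[nH]c(=O)c2)cc1` - 45000 nM

In a functional assay on MCF7 cells (Homo sapiens) for antiproliferative activity, read by MTT assay, with a stated time of 96 h (a higher number here means a weaker inhibitor, a lower number a stronger inhibitor), compound 2 gives 500 nM and sits at the low, stronger end of these numbers, level within the scatter with its nearest neighbour and far from its furthest. Compound 4 `COc1ccc(-c2cc(-c3ccc(O)c(O)c3)cc(=O)[nH]2)c(OC)c1` puts 3,4-dihydroxyphenyl in place of the 4-methoxyphenyl of compound 2, on an aromatic carbon opposite the ring nitrogen (3,4-dihydroxyphenyl in place of 4-methoxyphenyl on an aromatic carbon). For the measured compounds named here, two measured steps touch this same group. Taking a methoxy off it gave no change beyond the scatter (a 2.0-fold lower number from compound 1 to compound 2 (0.30 log units; within the scatter)). Lengthening its methoxy by an ethyl gave a large rise (a 90-fold higher number from compound 2 to compound 3 (1.95 log units; beyond the scatter)). Compound 4 carries no longer chain like compound 3 at 45000 nM and so a rise of that size is not expected. Going by the values given here, still, no measured compound has free hydroxyl groups, so some loss is allowed for. In this assay a small rise is therefore expected (a 3.0-fold higher number from compound 2 to compound 4 (0.48 log units; beyond the scatter)). Compound 4 is expected at 1500 nM (estimated range 250 nM to 9000 nM).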

Compound 4, half-maximal inhibitory concentration: 1500 nM
For compound 4 middle estimate and measured number coincide at the digits printed, within the range that was stated.
By their numbers in this assay, from the lowest: compounds 2, 1 and 4 (each within the scatter of the next, the first and the last beyond it); then compound 3.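

In this assay, replacing 4-methoxyphenyl with 3,4-dihydroxyphenyl gives a 3.0-fold higher number from compound 2 to compound 4 (0.48 log units; beyond the scatter), a real but modest loss, which shows that this position opposite the ring nitrogen can carry free hydroxyl groups, with 2 hydrogen-bond donors entering where the group that leaves has 0. The earlier compounds shown here varied only the ether groups on this ring, and lengthening the methoxy chain gave a 90-fold higher number from compound 2 to compound 3 (1.95 log units; beyond the scatter), a much larger step than this one. Nothing measured here explains why the number rises with the hydroxyl groups.

Because compound 4 changes the group in more than one way, the compounds shown cannot separate the effect of losing the methoxy from that of adding each hydroxyl. Also open, as far as these compounds go, is how this position would respond to an amine or a carboxylic acid on the same ring.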